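Aryl Variation on the Core Nitrogen and Cytotoxicity

The source may hold more compounds than are shown below. What is called first, only, known or untested is meant among the compounds shown, and "the series" means these compounds.

Measured compounds:
compound 1, `Oc1cc(C(F)(F)F)ccc1-c1nc(-c2ccccc2O)n(-c2ccc(Cl)cc2)n1`, 96.1%
compound 2, `Oc1cc(C(F)(F)F)ccc1-c1nc(-c2ccccc2O)n(-c2ccccc2C(F)(F)F)n1`, 92.2%
compound 3, `Cc1ccc(-n2nc(-c3ccc(C(F)(F)F)cc3O)nc2-c2ccccc2O)c(C)c1`, 106%

Three compounds sharing one core were tested in a functional assay on PC-12 cells (Rattus norvegicus) for cytotoxicity, read by MTT assay, with stated times of 2 h and 24 h, tested at 10 uM; a higher number here means a stronger effect of the compound at the concentration tested, a lower number a weaker effect. Compound 1 gives 96.1%, and its number lies between those of compound 2 and compound 3; the step of a number 3.9 percentage points lower from compound 1 to compound 2 (within the scatter) and the step of a number 9.9 percentage points higher from compound 1 to compound 3 (within the scatter) are both within the scatter, so compound 1 cannot be separated from either neighbour on these numbers. For the measured compounds named here, only the step of a number 13.8 percentage points higher from compound 2 to compound 3 (beyond the scatter) reaches beyond the scatter, and even that is modest.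

Compound 4, `Oc1cc(C(F)(F)F)ccc1-c1nc(-c2ccccc2O)n(-c2ccc(F)cc2F)n1`, has not yet been measured. It differs from compound 1 in one place: 2,4-difluorophenyl in place of 4-chlorophenyl on an aromatic nitrogen. The two steps that bear on this change are those from compound 1 to its two neighbours, which swap the same aryl group on the same aromatic nitrogen, and both stay within the scatter. Compound 4 is therefore expected to give a number close to that of compound 1, with the step of a number 1.1 percentage points lower from compound 1 to compound 4 (within the scatter) expected to lie within the scatter in either direction. The estimate for compound 4 in this assay is 95%, with a range from 80% to 108%.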

Compound 4, a percentage reported as activity, at one concentration (the size of the read-out at that concentration, not a potency): 97.9%
The estimate for compound 4 lay 2.9 percentage points below the measured number; the measured number falls inside the stated range.
By their numbers in this assay, from the lowest: compounds 2, 1, 4 and 3 (each within the scatter of the next, the first and the last beyond it).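

In this assay, the 2,4-difluorophenyl group of compound 4 cannot be told apart from any of the three earlier aryl groups on this aromatic nitrogen: the steps are a number 1.8 percentage points higher from compound 1 to compound 4 (within the scatter) and a number 5.7 percentage points higher from compound 2 to compound 4 (within the scatter) and a number 8.1 percentage points lower from compound 3 to compound 4 (within the scatter) for the three comparisons. The earlier compounds shown here left a gap at this position, a number 13.8 percentage points higher from compound 2 to compound 3 (beyond the scatter), and compound 4 falls within the scatter of both ends of it, so the new aryl group neither widens that gap nor assigns itself to either end. No measurement is available that would account for these small differences among the aryl groups.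

The aryl groups shown all keep a six-membered aromatic ring of carbon only and carry only chlorine, fluorine, trifluoromethyl or methyl, so it remains open whether an amine or a carboxylic acid on that ring, or a longer alkyl chain in place of the ring, would move the number beyond the scatter. Each compound also has a single read-out at one concentration, which leaves open how the effect changes with concentration.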